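Ester of the bicyclic acid: an unmeasured variant

This account rests on a few compounds, and the source may have more. Where it says the series, first, only, none or still open, it means among the compounds named here.

Compound 1 `COC(=O)Cc1c[nH]c(=O)c2cccn12` and compound 2 `O=C(O)CC1CNC(=O)c2ccc(Br)n21` are the measured members of the series. In a functional assay on PC-3 cells (Homo sapiens) for cytotoxicity, read by CCK-8 assay, with a stated time of 72 h (a higher number here means a weaker inhibitor, a lower number a stronger inhibitor), compound 1 gives > 200000 nM, which is a limit of the assay rather than a number. In this assay compound 2 gives > 200000 nM, again a limit. Compound 2 therefore stands at the limit of > 200000 nM in this assay, at which 2 of the 2 values shown sit. Compound 3 `CCOC(=O)CC1CNC(=O)c2ccc(Br)n21` differs from compound 2 by ethyl in place of hydrogen on an oxygen next to a carbonyl group. Among the measured compounds shown here, no step between measured compounds is available, so no shift beyond the scatter is expected in this assay, and the expected step is a number no higher from compound 2 to compound 3 (the limit leaves the size open). Compound 3 is expected to give 200000 nM, with a range from 60000 nM to 600000 nM, most likely reported again as a limit.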

Compound 3, half-maximal inhibitory concentration: 29000 nM
Compound 3: the middle estimate sits 6.9-fold (0.84 log units) above what was measured, outside the stated range (below it).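

In this assay, ethyl in place of hydrogen on an oxygen next to a carbonyl group gives an at least 6.8-fold lower number from compound 2 to compound 3 (0.83 log units; beyond the scatter). Among the compounds shown here, this makes the oxygen of the carboxy group a position where a change can move the read-out, and compound 3 gives the first value that is a number. The value of compound 2 is a limit, so the full size of the step stays open: the limit of > 200000 nM in this assay, at which 2 of the 3 values shown sit.

From the compounds shown here alone, whether the step is specific to ethoxycarbonyl remains open. A longer chain such as butyl on this oxygen, or an amine in place of the ethoxy group, would test that.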